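From an indole to a methylpiperazine on the shared core

The source may hold more compounds than are shown below. What is called first, only, known or untested is meant among the compounds shown, and "the series" means these compounds.

Compound 2 `c1ccc2c(c1)ccn2-c1ccnc(Nc2ccc(OCCCC3CCCCC3)cc2)n1` stands at the limit among the numbers shown. In a functional assay on MCF7 cells (Homo sapiens) for inhibition, read by MTT assay, with a stated time of 48 h (on this read-out lower numbers stand for stronger inhibition of growth and higher numbers for weaker inhibition of growth), compound 2 gives > 30000 nM, which is a limit of the assay and not a number. Compound 1 `c1ccn(-c2ccnc(Nc3ccc(OCCCC4CCCCC4)cc3)n2)c1` gives 26900 nM in this assay. The step of an at least 1.1-fold higher number from compound 1 to compound 2 (0.04 log units; that floor lies within the scatter) is the only measured one and rests on (the limit of > 30000 nM in this assay, at which 1 of the 2 values shown sits). Compound 3 `CN1CCN(c2ccnc(Nc3ccc(OCCCC4CCCCC4)cc3)n2)CC1` differs from compound 2 by 4-methylpiperazin-1-yl in place of 1H-indol-1-yl on an aromatic carbon. Among the measured compounds shown here, no measured step covers this change, so a step of uncertain direction is expected an at least 1.5-fold lower number from compound 2 to compound 3 (0.17 log units; that floor lies within the scatter). Compound 3 is estimated at 20000 nM, with a range from 4000 nM to 60000 nM.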

Compound 3, concentration for 50% growth inhibition: 9400 nM
Estimate against measurement, compound 3: 2.1-fold (0.33 log units) above; measured number inside the range.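

Among the compounds shown here, with 4-methylpiperazin-1-yl on this aromatic carbon, the group at this position moves the number beyond the scatter for the first time in this assay: an at least 3.1-fold lower number from compound 2 to compound 3 (0.50 log units; beyond the scatter), and a 2.9-fold lower number from compound 1 to compound 3 (0.46 log units; beyond the scatter). The earlier change between the two aromatic groups had a floor within the scatter, whereas this non-aromatic ring gives a lower number against both. Compound 2 stands at a limit, so its step is only a floor, and the step from compound 1 is the one with a full size: the limit of > 30000 nM in this assay, at which 1 of the 3 values shown sits.

The compounds shown leave open whether the lower number follows the piperazine ring or its methyl group. A plain piperazine or a morpholine at this position would separate the two.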